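Swapping the Pyrazole for an Oxazole: Expected Clearance

The source may report more compounds than this note shows. Statements on the series, on what has been measured and on what is new or still open speak of the compounds shown alone.

Among the measured compounds shown here, compound 1 `Cc1c(Cc2ccc(-n3cccn3)cc2)cc(C(=O)N[C@H]2CCCC[C@@H]2O)c(=O)n1C` gives 20 mL/min/kg in an ADME assay on microsomes from liver (Homo sapiens) for metabolic stability (on this read-out higher numbers stand for fast clearance and lower numbers for slow clearance), and is the only compound with a plain number there. Compound 2 `Cc1c(Cc2ccc(-n3cccn3)cc2)cc(C(=O)N[C@H]2CCOC[C@@H]2O)c(=O)n1C` reaches only the assay limit of < 8 mL/min/kg in this assay. For the measured compounds named here, the single measured step of an at least 2.5-fold lower number from compound 1 to compound 2 (0.39 log units; beyond the scatter) alters the ring on the amide nitrogen. Going by the values given here, compound 3 `Cc1c(Cc2ccc(-c3cocn3)cc2)cc(C(=O)N[C@H]2CCCC[C@@H]2O)c(=O)n1C` instead carries 1,3-oxazol-4-yl in place of 1H-pyrazol-1-yl on an aromatic carbon and so differs from compound 1 at a place no measured step has touched. A result near that of compound 1 is therefore expected and compound 3 is estimated at 20 mL/min/kg with a range from 10 mL/min/kg to 40 mL/min/kg which means no change at the digits printed from compound 1 to compound 3 (within the scatter) beyond nothing the scatter would hide.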

Compound 3, clearance: 17 mL/min/kg
Beside the measured number, compound 3's estimate is 1.2-fold (0.07 log units) above it, and the stated range covers the measured number.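

In this assay, replacing 1H-pyrazol-1-yl with 1,3-oxazol-4-yl on the aromatic carbon para to a large group gives a 1.2-fold lower number from compound 1 to compound 3 (0.07 log units; within the scatter). The read-out therefore does not separate these two five-membered aromatic rings, which have the same heavy-atom count but differ by one nitrogen traded for one oxygen. Nothing shown here gives a reason for this result.

A morpholine or an open-chain amine at this place remains untested in the compounds shown. Also open, going by these compounds, is how 1,3-oxazol-4-yl behaves alongside the 3-hydroxyoxan-4-yl group of compound 2.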